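A few compounds are considered here, and "the series" means these few. Any claim that something is new, unique, unknown or untested is made for them only; others in the source may bear on it.

Compound 1 `O=C(Nc1cc(Cl)cc(Cl)c1)c1cnc(Cl)nc1C(F)(F)F` is the smaller of the two measured compounds; in an assay on Jurkat cells for inhibition of cyclic AMP-dependent transcription factor ATF-1 (Homo sapiens) (on this read-out higher numbers stand for weaker inhibition and lower numbers for stronger inhibition), compound 1 gives 500 nM. Compound 2 `CCCCNC(=O)c1cc(NC(=O)c2cnc(Cl)nc2C(F)(F)F)cc(C(F)(F)F)c1` carries a butylcarbamoyl group on the amide-bearing ring of the shared core. In this assay compound 2 reaches only a limit, > 10000 nM, so no number is known for it. That limit, (the limit of > 10000 nM in this assay, at which 1 of the 2 values shown sits), is where one of the two measured values sits. Compound 3 `CCCCCCCCOC(=O)c1cc(NC(=O)c2cnc(Cl)nc2C(F)(F)F)cc(C(F)(F)F)c1` differs from compound 2 in one place: octyloxy in place of butylamino on a carbonyl carbon. Among the measured compounds shown here, no measured pair isolates a change of this kind, so nothing measured sets the size of the step; in this assay the expected step that the limit leaves unreadable from compound 2 to compound 3 is small and in no clear direction beyond the usual scatter. Compound 3 is therefore expected at about 15000 nM, within a range from 5000 nM to 50000 nM, and most likely again only as a limit.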

Compound 3, half-maximal inhibitory concentration: 1200 nM
Beside the measured number, compound 3's estimate is 13-fold (1.10 log units) above it, and the stated range ends above it.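

In this assay, the group on this carbonyl carbon proves able to move the read-out: the change from butylcarbamoyl to octyloxycarbonyl gives an at least 8.3-fold lower number from compound 2 to compound 3 (0.92 log units; beyond the scatter). Compound 2 therefore does not show that the position as a whole is closed to inhibition, since compound 3, with the same remaining structure, returns a measured number. The step can be given only as a minimum, because one end of it is a limit: the limit of > 10000 nM in this assay, at which 1 of the 3 values shown sits.

The change swaps the linking nitrogen and its amide hydrogen for an oxygen and lengthens the chain in the same move, so the compounds shown leave open which of these carries the step. A butoxy or an octylamino group on the same carbonyl carbon would separate the two, and a carboxylic acid there remains an open case.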